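The compounds below may be only part of what the source reports. "The series", "measured", "known", "first", "only" and "open" are said of these compounds alone.

For the measured compounds named here, in a functional assay on SW480 cells (Homo sapiens) for antiproliferative activity, read by MTT assay, with a stated time of 48 h (on this read-out higher numbers stand for weaker inhibition and lower numbers for stronger inhibition), compound 2 `CCCCCCCCC(CCO)n1cnc2c(NC)ncnc21` gives 3770 nM, the lower of the two exact numbers so far. Compound 1 `CCCCCC(CCO)n1cnc2c(NC)ncnc21` reaches only a limit, > 50000 nM. Compound 3 `CCCCCCCCC(CCO)n1cnc2c(N)ncnc21` gives 20700 nM, a modest change: a 5.5-fold higher number from compound 2 to compound 3 (0.74 log units; beyond the scatter). Compound 4 `CCCCCCCCCCCC(CCO)n1cnc2c(NC)ncnc21` keeps the core of compound 2 and extends its chain: propyl in place of hydrogen on a saturated chain carbon, nine bonds along the chain from an aromatic nitrogen. Going by the values given here, the only comparable change is an at least 13-fold lower number from compound 1 to compound 2 (1.12 log units; beyond the scatter), a large step that starts from a limit, so its true size is unknown. One precedent is thin support, so a smaller step in the same direction, toward stronger inhibition, is expected: an estimated 2.5-fold lower number from compound 2 to compound 4 (0.40 log units; beyond the scatter). Compound 4 is expected near 1500 nM, with an estimated range of 350 nM to 7000 nM.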

Compound 4, half-maximal inhibitory concentration: 12800 nM
The estimate for compound 4 lay 8.5-fold (0.93 log units) below the measured number; the measured number lies above the stated range.
By their numbers in this assay, from the lowest: compound 2; then compounds 4 and 3 (each within the scatter of the next). At a limit, above all of these: compound 1.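

Propyl in place of hydrogen, which gave stronger inhibition when it extended the chain of compound 1, gives weaker inhibition here, nine bonds along the chain from an aromatic nitrogen: a 3.4-fold higher number from compound 2 to compound 4 (0.53 log units; beyond the scatter). A longer chain therefore does not keep lowering the number, although the longest chain still compares well with the shortest: an at least 3.9-fold lower number from compound 1 to compound 4 (0.59 log units; beyond the scatter). Compound 1 stands at a limit, so that last step is only a bound: the limit of > 50000 nM in this assay, at which 1 of the 4 values shown sits.

Still open, on these data alone, is whether a chain of a length between those of compound 2 and compound 4 would give a lower number. Also open, as far as these compounds go, is how an amine or a carboxylic acid in place of the hydroxyl would read.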